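A few compounds are considered here, and "the series" means these few. Any claim that something is new, unique, unknown or untested is made for them only; others in the source may bear on it.

Values so far in a functional assay on the whole organism for antagonist activity, with Mus musculus as the target (on this read-out higher numbers stand for an effect only at larger amounts of compound and lower numbers for an effect already at smaller amounts), are these
Compound 1 `CC(=O)N(C)C(C)C#CCn1cncc1C` gives 3.7 mg/kg
Compound 2 `CCOC(=O)N(C)CC#CCn1cncc1C` gives 66 mg/kg
Compound 3 `CCOC(=O)N(C)C(C)C#CCN1CCCC1` gives > 100 mg/kg as a limit

Compound 3 has only a limit and not a number, and the record shows the limit of > 100 mg/kg in this assay, at which 1 of the 3 values shown sits, in this set.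

Compound 4 `CCOC(=O)N(C)C(C)C#CCn1cncc1C` changes one group of compound 3. The change 5-methyl-1H-imidazol-1-yl in place of pyrrolidin-1-yl on a saturated chain carbon bound to a triple-bonded carbon brings 5-methyl-1H-imidazol-1-yl in place of pyrrolidin-1-yl on a saturated chain carbon bound to a triple-bonded carbon.

Compound 1 already carries 5-methyl-1H-imidazol-1-yl and gives 3.7 mg/kg as a true number. Compound 2 carries the same group and gives 66 mg/kg as a true number too. Both differ from compound 4 elsewhere in the molecule and their values lie far apart, so they guide the estimate only loosely.

The expected change is an at least 6.6-fold lower number from compound 3 to compound 4 (0.82 log units; beyond the scatter) and would go beyond the scatter toward an effect at smaller amounts. The estimated value for compound 4 is 15 mg/kg with an expected range from 4 mg/kg to 60 mg/kg in this assay once it is measured.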

Compound 4, dose for half-maximal effect: 17.3 mg/kg
Estimate against measurement, compound 4: 1.2-fold (0.06 log units) below; measured number inside the range.
By their numbers in this assay, from the lowest: compound 1; then compound 4; then compound 2. At a limit, above all of these: compound 3.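

With 5-methyl-1H-imidazol-1-yl in place of pyrrolidin-1-yl on a saturated chain carbon bound to a triple-bonded carbon, this assay shows an at least 5.7-fold lower number from compound 3 to compound 4 (0.76 log units; beyond the scatter) and so gives this position its first direct comparison. Compound 3 carries only a limit and not a number: the limit of > 100 mg/kg in this assay, at which 1 of the 4 values shown sits. Compound 4 also links the two compounds that already carried this group: methyl in place of hydrogen on a saturated chain carbon bound to an amide-type nitrogen and a triple-bonded carbon gives a 3.8-fold lower number from compound 2 to compound 4 (0.58 log units; beyond the scatter) and ethoxy in place of methyl on a carbonyl carbon gives a 4.7-fold higher number from compound 1 to compound 4 (0.67 log units; beyond the scatter) and these two changes move the number in opposite directions.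

From the compounds shown here alone, whether the ring's methyl matters stays open, as does how a plain imidazol-1-yl, a piperidin-1-yl or a dimethylamino group would compare at this place. Also open, going by these compounds, is how a longer chain such as propoxy on the carbonyl carbon would compare with ethoxy.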